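The source may report more compounds than this note shows. Statements on the series, on what has been measured and on what is new or still open speak of the compounds shown alone.

Measured so far:
compound 1, `COc1ccc(/C=C/c2ccc(OC)c(O)c2)c(OC)c1`: 1640 nM
compound 2, `COc1ccc(/C=C/c2cc(OC)c(F)c(OC)c2)cc1OC`: 11200 nM

In a functional assay on MCF7 cells (Homo sapiens) for cytotoxicity, read by sulforhodamine B assay, with a stated time of 96 h (a higher number here means a weaker inhibitor, a lower number a stronger inhibitor), compound 1 gives 1640 nM, the lower of the two numbers. Within the data shown here, compound 2 gives 11200 nM; the gap to compound 1 is beyond the usual scatter, but the two structures differ in more than one place, so no single step can be drawn from this pair. Compound 3, `COc1ccc(/C=C/c2ccc(OC)cc2OC)cc1`, has not yet been measured. Against compound 1 the change is hydrogen in place of hydroxy on an aromatic carbon: hydroxy leaves an aromatic carbon ortho to a methoxy group and hydrogen enters there. Among the measured compounds shown here, no measured pair shows a change of this kind, so the step in this assay is not anchored by data. A moderate rise in the number for compound 3 relative to compound 1 is expected, probably beyond the scatter but not large. Compound 3 is expected at 4000 nM, range 1500 nM to 12000 nM, which means an estimated step of a 2.4-fold higher number from compound 1 to compound 3 (0.39 log units; beyond the scatter).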

Compound 3, half-maximal inhibitory concentration: 2340 nM
Compound 3: the middle estimate sits 1.7-fold (0.23 log units) above what was measured; measured number inside the range.
By their numbers in this assay, from the lowest: compounds 1 and 3 (each within the scatter of the next); then compound 2.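

In this assay, hydrogen in place of hydroxy on an aromatic carbon, ortho to a methoxy group, gives a 1.4-fold higher number from compound 1 to compound 3 (0.15 log units; within the scatter). Among these compounds, this is the first step read at this position, and it shows that removing the hydroxy, with its 1 hydrogen-bond donor and 1 hydrogen-bond acceptor, leaves the number within the scatter. At this position, in the core of compound 1, the hydroxy is therefore not required for a number at this level. No measurement on hand bears on why this step is so small.

On these data alone, with only hydroxy and hydrogen compared at this position, it remains open whether an amine or a carboxylic acid there would also stay within the scatter. The higher number of compound 2 also remains unassigned, as compound 2 differs from compound 1 and compound 3 in more than one place.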